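A few compounds are considered here, and "the series" means these few. Any claim that something is new, unique, unknown or untested is made for them only; others in the source may bear on it.

In a functional assay (plasma) with Oryctolagus cuniculus as the target (on this read-out higher numbers stand for weaker inhibition and lower numbers for stronger inhibition), compound 1 `Cc1nc2cnccc2n1CC1CCN(C(=O)CC(C)(O)c2ccccc2)CC1` gives 6.9 nM and compound 2 `Cc1nc2cnccc2n1CC1CCN(C(=O)N[C@H](C)c2ccccc2)CC1` gives 13 nM while compound 3 `Cc1nc2cnccc2n1CC1CCN(C(=O)N[C@@H](C)c2ccccc2)CC1` gives 41 nM as the highest number of the three. Within the data shown here, the one measured step is a 3.2-fold higher number from compound 2 to compound 3 (0.50 log units; beyond the scatter) and it is due to the fact that compounds 2 and 3 differ only in the configuration as drawn alone. Compound 4 `Cc1nc2cnccc2n1CC1CCN(C(=O)CN(C)c2ccccc2)CC1` joins the same atoms as compound 3 differently ((methyl(phenyl)amino)methyl in place of (1-phenylethyl)amino on a carbonyl carbon) so that step bears on it only loosely, as a sign of how far a change in this group can move the number. Compound 1 at 6.9 nM also has a carbon on the carbonyl carbon, which hints at a lower number, so the expected change is a 1.6-fold lower number from compound 3 to compound 4 (0.21 log units; within the scatter) and no step beyond the scatter is expected. For compound 4 the expected value in this assay is 25 nM with an estimated range from 7 nM to 90 nM overall.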

Compound 4, half-maximal inhibitory concentration: 23 nM
The estimate for compound 4 lay 1.1-fold (0.04 log units) above the measured number; low and high end bracket the measured number.
By their numbers in this assay, from the lowest: compounds 1, 2, 4 and 3 (each within the scatter of the next, the first and the last beyond it).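

Replacing (1-phenylethyl)amino with (methyl(phenyl)amino)methyl on the carbonyl carbon removes the hydrogen-bond donor and the defined stereocentre, yet in this assay the result stays within the scatter of both mirror-image forms, with a 1.8-fold lower number from compound 3 to compound 4 (0.25 log units; within the scatter) and a 1.8-fold higher number from compound 2 to compound 4 (0.25 log units; within the scatter). Compound 1 differs from compound 4 on the saturated chain carbon bound to the carbonyl carbon, and methyl(phenyl)amino in place of 1-hydroxy-1-phenylethyl gives a 3.3-fold higher number from compound 1 to compound 4 (0.52 log units; beyond the scatter). No measurement shown explains these steps. As far as these compounds go, how a carboxylic acid or a longer chain would read on that saturated chain carbon remains open.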